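The source may report more compounds than this note shows. Statements on the series, on what has been measured and on what is new or still open speak of the compounds shown alone.

The series shares a common core carrying a nitrile-bearing group and a pyridinyl amine, varied only at the substituent on the double-bonded nitrogen. Compound 1 `CCC(C)/N=C(\NC#N)Nc1cccnc1` gives 20 mg/kg in a functional assay on the whole organism (blood, strain Wistar-Okamoto) with Rattus norvegicus as the target, with a stated time of 5 days; on this read-out lower numbers stand for an effect already at smaller amounts and higher numbers for an effect only at larger amounts of compound. Among the three measured compounds it holds the second highest number: compound 3 `CC(C)(C)C(C)(C)/N=C(\NC#N)Nc1cccnc1` gives 50 mg/kg, a higher number, and compound 2 `CC(C)CC(C)(C)/N=C(\NC#N)Nc1cccnc1` gives 2.5 mg/kg, the lowest number of the three. For the measured compounds named here, the only single-point step measured so far is a 20-fold higher number from compound 2 to compound 3 (1.30 log units; beyond the scatter), a large rise in the number for tert-butyl in place of isobutyl on a saturated chain carbon bound to a double-bonded nitrogen and two saturated chain carbons.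

Compound 4 `N#CN/C(=N\CC1CCCO1)Nc1cccnc1` differs from compound 1 as follows: (oxolan-2-yl)methyl in place of sec-butyl on a double-bonded nitrogen. Going by the values given here, the entering group brings a five-membered non-aromatic ring with one hetero atom and one hydrogen-bond acceptor, and none of the measured compounds carries such a ring or acceptor. The step from compound 2 to compound 3 concerns branching among saturated chains and does not speak directly to this exchange. Compound 4 is therefore expected to lie close to compound 1, with a step of a 1.3-fold higher number from compound 1 to compound 4 (0.10 log units; within the scatter) expected to remain within the scatter. The estimate for compound 4 in this assay is 25 mg/kg, with a range from 8 mg/kg to 80 mg/kg.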

Compound 4, minimum effective dose: 50 mg/kg
The estimate for compound 4 lay 2.0-fold (0.30 log units) below the measured number, within the range that was stated.
By their numbers in this assay, from the lowest: compound 2; then compound 1; then compounds 3 and 4 (each within the scatter of the next).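

In this assay the exchange of sec-butyl for (oxolan-2-yl)methyl on a double-bonded nitrogen gives a 2.5-fold higher number from compound 1 to compound 4 (0.40 log units; beyond the scatter) and so lies beyond the scatter. For the compounds shown here, this is the first measured change at this position that brings in a ring and a hydrogen-bond acceptor, and here they go with a modest rise in the number, whereas the earlier step of a 20-fold higher number from compound 2 to compound 3 (1.30 log units; beyond the scatter) concerned only saturated chains. Nothing measured here accounts for the rise.

Left open is whether the step follows the five-membered ring or its oxygen, a question that a cyclopentylmethyl group on the same nitrogen would separate. Also open, going by these compounds, is how an open chain carrying an ether oxygen, such as 2-methoxyethyl, or an amine on a short chain would compare with sec-butyl at this position.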